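The source may hold more compounds than are shown below. What is called first, only, known or untested is meant among the compounds shown, and "the series" means these compounds.

Measured compounds in a functional assay on HCC1806 cells (Homo sapiens) for inhibition, read by sulforhodamine B assay, tested at 10 uM; on this read-out higher numbers stand for more inhibition at the one concentration tested (going by the name of the read-out) and lower numbers for less inhibition:
- compound 1 `CN1CCN(c2ccc(C3=NN(C(=O)/C=C/c4ccccc4)C(c4ccc(N(C)C)cc4)C3)cc2)CC1`: 71%
- compound 2 `CN1CCN(c2ccc(C3=NN(S(=O)(=O)c4ccc(F)cc4)C(c4ccc(N(C)C)cc4)C3)cc2)CC1`: 92.3%
- compound 3 `CC(=O)N1N=C(c2ccc(-n3cncn3)cc2)CC1c1ccc(N(C)C)cc1`: 11%

Compound 3 stands lowest of the three numbers in this assay. Its nearest neighbour is compound 1, higher by a margin beyond the scatter; the furthest is compound 2, higher still. Within the data shown here, the one step measured is on the amine nitrogen in the ring of the shared core: a number 21.3 percentage points higher from compound 1 to compound 2 (beyond the scatter). Compound 1 and compound 2 differ from compound 3 in two places at once (the group on that nitrogen and the substituent on the phenyl ring), so their values show only that the two larger aryl-bearing groups on the ring nitrogen sit far above the acetyl compound.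

Compound 4 `CN(C)c1ccc(C2CC(c3ccc(-n4cncn4)cc3)=NN2C(=O)c2ccc(C(F)(F)F)cc2)cc1` is the next member and keeps the core of compound 3. The change is 4-(trifluoromethyl)phenyl in place of methyl on a carbonyl carbon. The step from compound 1 to compound 2 bears on it only loosely: it concerns the same nitrogen, but no acetyl and no aroyl group is among the measured groups there. Given that compound 1 and compound 2 both sit well above compound 3, an upward step is expected for compound 4, of uncertain size: a number 34 percentage points higher from compound 3 to compound 4 (beyond the scatter). Compound 4 is estimated at 45%, with a range from 15% to 75%.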

Compound 4, a percentage reported as inhibition, at one concentration (the size of the read-out at that concentration, not a potency): 7%
Compound 4: the middle estimate sits 38 percentage points above what was measured; the measured number lies below the stated range.
By their numbers in this assay, from the lowest: compounds 4 and 3 (each within the scatter of the next); then compound 1; then compound 2.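

In this assay, the position on the carbonyl carbon whose other neighbours are an amide-type nitrogen in a ring now has a measured one-place change, with a number 4 percentage points lower from compound 3 to compound 4 (within the scatter). On the core of compound 3, then, 4-(trifluoromethyl)phenyl and methyl at this position cannot be told apart, so exchanging methyl for this much larger group carrying a six-membered aromatic ring does not on its own separate the two compounds on this read-out. No available evidence bears on this result.

As far as these compounds go, compound 1 and compound 2 still differ from compound 4 in more than one place, so it remains open whether their (2-phenylethenyl)carbonyl and (4-fluorophenyl)sulfonyl groups would give high numbers on the core of compound 3, or whether the substituent on the phenyl ring accounts for the gap. Also open, from the compounds shown here alone, is whether a carboxylic acid or an amine in place of trifluoromethyl on the aromatic ring, or a longer chain in place of methyl on the carbonyl carbon, would move the number on this core.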